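The source may hold more compounds than are shown below. What is called first, only, known or untested is meant among the compounds shown, and "the series" means these compounds.

Measured in a functional assay on B16-F0 cells (Mus musculus) for inhibition, read by CCK-8 assay, with a stated time of 48 h; on this read-out higher numbers stand for weaker inhibition and lower numbers for stronger inhibition:
- Compound 1 `COc1cc(-c2ccnc3cc(-c4ccc(Cl)cc4)nn23)cc(OC)c1OC`: 4090 nM
- Compound 2 `COc1cc(-c2ccnc3cc(-c4ccc5c(ccn5C)c4)nn23)cc(OC)c1OC`: 48 nM
- Compound 3 `COc1cc(-c2ccnc3cc(-c4ccc(C(C)=O)cc4)nn23)cc(OC)c1OC`: 3930 nM

Compound 3, at 3930 nM, stands with compound 1 at the high end of the three numbers, the step of a 1.0-fold lower number from compound 1 to compound 3 (0.02 log units; within the scatter) separating them. The remaining gap is large: an 82-fold higher number from compound 2 to compound 3 (1.91 log units; beyond the scatter).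

Compound 4 `COc1cc(-c2ccnc3cc(-c4ccc5ccn(C)c5c4)nn23)cc(OC)c1OC` differs from compound 3 as follows: 1-methyl-1H-indol-6-yl in place of 4-acetylphenyl on an aromatic carbon. In words, 1-methyl-1H-indol-6-yl replaces 4-acetylphenyl on an aromatic carbon.

Two large steps bear on this change, an 85-fold lower number from compound 1 to compound 2 (1.93 log units; beyond the scatter) and an 82-fold higher number from compound 2 to compound 3 (1.91 log units; beyond the scatter). Both involve 1-methyl-1H-indol-5-yl, the group carried by compound 2. Going by the values given here, no compound with 1-methyl-1H-indol-6-yl has been measured, so how far those steps carry over remains open. A large step to a lower number is expected in this assay, probably somewhat short of the gap seen with compound 2.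

The estimated step is a 26-fold lower number from compound 3 to compound 4 (1.42 log units; beyond the scatter). For compound 4 the expected value is 150 nM, with an estimated range of 30 nM to 1000 nM.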

Compound 4, half-maximal inhibitory concentration: 657 nM
Compound 4: the middle estimate sits 4.4-fold (0.64 log units) below what was measured, and the stated range covers the measured number.
By their numbers in this assay, from the lowest: compound 2; then compound 4; then compounds 3 and 1 (each within the scatter of the next).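

In this assay the 1-methyl-1H-indol-5-yl and 1-methyl-1H-indol-6-yl groups are not interchangeable on this aromatic carbon, with a 14-fold higher number from compound 2 to compound 4 (1.14 log units; beyond the scatter) as the result of that single change, so the attachment point of the group matters and not just its presence. The 1-methyl-1H-indol-6-yl group still gives lower numbers than either phenyl group, with a 6.0-fold lower number from compound 3 to compound 4 (0.78 log units; beyond the scatter) and a 6.2-fold lower number from compound 1 to compound 4 (0.79 log units; beyond the scatter) as the two modest steps, so only part of the gain seen with compound 2 survives the shift. No data are available to explain the difference between the two attachment points.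

From the compounds shown here alone, it remains open whether a 1H-indol-5-yl group without the methyl, or a 1-methyl-1H-indol-4-yl group, would match compound 2 in this assay at this carbon. Also open, going by these compounds, is whether an aminomethyl group in place of acetyl on the phenyl ring would move the number away from that of compound 3.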